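Replacing the pyrazolyl on the amide nitrogen of compound 1

The source may report more compounds than this note shows. Statements on the series, on what has been measured and on what is new or still open speak of the compounds shown alone.

Measured compounds:
compound 1 `Cc1ccc(OCC(=O)N(Cc2cccs2)c2c(C)n[nH]c2C)cc1`: 0.3 nM
compound 2 `CCN(Cc1cccs1)C(=O)COc1ccccc1`: 1400 nM

In an assay on HEK293 cells for agonist activity at transient receptor potential cation channel subfamily M member 8 (Homo sapiens), read by fluorescence and calcium flux, with a stated time of 15 min (on this read-out lower numbers stand for an effect already at smaller amounts and higher numbers for an effect only at larger amounts of compound), compound 1 gives 0.3 nM, the lowest of the two numbers shown. Going by the values given here, the only other compound, compound 2, gives 1400 nM in this assay, a much higher number and well beyond the scatter; the two structures differ in more than one place, so no single step between them can be read off.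

Compound 3 `Cc1ccc(OCC(=O)N(O)Cc2cccs2)cc1` has not yet been measured. It is derived from compound 1 by one change: hydroxy in place of 3,5-dimethyl-1H-pyrazol-4-yl on an amide-type nitrogen. Among the compounds with values here, no measured pair shows this change directly, so the expectation rests on the two values at hand. Compound 2, which also lacks the larger group on the amide nitrogen, gives 1400 nM, so a large rise in this assay is expected from compound 1 to compound 3, a 2000-fold higher number from compound 1 to compound 3 (3.30 log units; beyond the scatter). For compound 3 the estimate is 600 nM, within a range of 40 nM to 8000 nM.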

Compound 3, half-maximal effective concentration: 8000 nM
Compound 3: the middle estimate sits 13-fold (1.12 log units) below what was measured, and the stated range covers the measured number.
By their numbers in this assay, from the lowest: compound 1; then compound 2; then compound 3.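

Going by these compounds alone, this is the first single change read at the amide-type nitrogen of compound 1: in this assay, hydroxy in place of 3,5-dimethyl-1H-pyrazol-4-yl gives a 27000-fold higher number from compound 1 to compound 3 (4.43 log units; beyond the scatter), so this position is highly sensitive to the change. The two groups carry the same counts of hydrogen-bond donors and acceptors but differ in ring and heavy atoms, so matching those counts did not preserve the low number of compound 1. No measurement presented here explains the size of this step.

On these data alone, it remains open whether a 1H-pyrazol-4-yl without the two methyl groups, or a phenyl ring, would hold the number near that of compound 1. A methoxy group or an amino group on the same nitrogen would also test whether the outcome seen with hydroxy extends to other small groups.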